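Adding a second chloro to the phenoxy ring of compound 2

The source may report more compounds than this note shows. Statements on the series, on what has been measured and on what is new or still open speak of the compounds shown alone.

Two compounds with a shared core of an anilide attached to an aryl piperidine have been measured in an assay on isolated protein for displacement of a labelled ligand from melanin-concentrating hormone receptor 1 (Rattus norvegicus); on this read-out lower numbers stand for stronger inhibition and higher numbers for weaker inhibition. Compound 1 `O=C(CCCN1CCC(c2cccc(NC(=O)C3CCCCC3)c2)CC1)c1ccc(Cl)cc1` gives 200 nM in this assay. Compound 2 `CC(C)C(=O)Nc1cccc(C2CCN(Cc3cccc(Oc4ccc(Cl)cc4)c3)CC2)c1` gives 23 nM in this assay, the lower of the two numbers; compound 1 stands a higher number away, a gap beyond the scatter. For the measured compounds named here, because the two compounds differ in more than one place, no single step between them can be read off, and the two values say only that compound 2 is the stronger of the pair.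

Compound 3 `CC(C)C(=O)Nc1cccc(C2CCN(Cc3cccc(Oc4ccc(Cl)c(Cl)c4)c3)CC2)c1` has not been measured. It differs from compound 2 in one place: chloro in place of hydrogen on an aromatic carbon, on an aromatic carbon of a six-membered aromatic ring of carbon only, ortho to a chloro group and meta to a large group, so that the 4-chlorophenoxy group becomes a 3,4-dichlorophenoxy group. Going by the values given here, no measured pair shows this change, so the step is estimated as small and not expected to lie beyond the scatter, its sign uncertain. Compound 3 is therefore expected to give about 15 nM in this assay, within a range of 5 nM to 45 nM, an estimated step from compound 2 to compound 3 of a 1.5-fold lower number from compound 2 to compound 3 (0.19 log units; within the scatter).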

Compound 3, inhibition constant: 18 nM
For compound 3 the middle estimate is 1.2-fold (0.08 log units) below the measured one; low and high end bracket the measured number.
By their numbers in this assay, from the lowest: compounds 3 and 2 (each within the scatter of the next); then compound 1.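

For the compounds shown here, the second chloro gives the first comparison that differs in only one place, and in this assay it turns the 4-chlorophenoxy group into a 3,4-dichlorophenoxy group with a 1.3-fold lower number from compound 2 to compound 3 (0.11 log units; within the scatter). This position on the aromatic ring, ortho to a chloro group and meta to a large group, therefore takes an added chloro without a shift beyond the scatter, and compound 2 and compound 3 cannot be told apart on this read-out. Nothing available here bears on why the number stays within the scatter when this chlorine enters.

The compounds shown leave open whether this same carbon would tolerate a different group, such as methoxy, a nitrile or an amine, or whether a chloro on another carbon of the ring would behave in the same way. They also leave open what the original 4-chloro group contributes, since neither compound 2 nor compound 3 lacks it, and whether a fluoro or a methyl group in its place would leave the number within the scatter.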